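The compounds below may be only part of what the source reports. "The series", "measured", "known", "first", "only" and "open" are said of these compounds alone.

Notes on the series. Compound 1 `COc1ccc(C(C)NC(=O)/N=C(\N)NCCCc2sc(N)nc2C)cc1`, compound 2 `Cc1nc(N)sc1CCCN/C(N)=N/C(=O)NCc1ccco1` and compound 3 `Cc1nc(N)sc1CCCN/C(N)=N/C(=O)NC(C)c1ccc(F)cc1` share one core and differ only in the group carried on the amide-type nitrogen. In a functional assay on Right cardiac atrium for agonist activity at histamine H2 receptor (Cavia porcellus), with a stated time of 30 min, in the presence of a further agent that is not named here (a higher number here means that more compound is needed for the effect, a lower number that less compound is needed), compound 1 gives 38 nM, compound 2 gives 11.8 nM and compound 3 gives 23.4 nM. Compound 3 thus stands second highest of the three numbers, nearest to compound 1 and furthest from compound 2, and neither gap is beyond the scatter. For the measured compounds named here, the one measured step that changes the aryl group, a 1.6-fold lower number from compound 1 to compound 3 (0.21 log units; within the scatter), stays within the scatter. Compound 4 `Cc1nc(N)sc1CCCN/C(N)=N/C(=O)NC(C)c1cccs1` is the next member, still to be measured in this assay; the change is thiophen-2-yl in place of 4-fluorophenyl on a saturated chain carbon bound to an amide-type nitrogen and a saturated chain carbon. Going by the values given here, compound 2 gives a number within the scatter of compound 3, but no single-point step links the two. Among the compounds with values here, with only one aryl-group step in hand, and that within the scatter, the expected step is a 1.3-fold lower number from compound 3 to compound 4 (0.11 log units; within the scatter), nothing beyond the scatter. Compound 4 is therefore expected to give about 18 nM in this assay, within a range from 8 nM to 40 nM.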

Compound 4, half-maximal effective concentration: 10 nM
Compound 4: the middle estimate sits 1.8-fold (0.26 log units) above what was measured, and the stated range covers the measured number.
By their numbers in this assay, from the lowest: compounds 4, 2, 3 and 1 (each within the scatter of the next, the first and the last beyond it).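

In this assay, for the compounds shown here, thiophen-2-yl on the saturated chain carbon bound to an amide-type nitrogen and a saturated chain carbon gives the first aryl change here that passes the scatter, with a 2.3-fold lower number from compound 3 to compound 4 (0.37 log units; beyond the scatter) and a 3.8-fold lower number from compound 1 to compound 4 (0.58 log units; beyond the scatter) as modest steps, whereas the step from 4-methoxyphenyl to 4-fluorophenyl stayed within it. The comparison with the other five-membered aromatic ring, a 1.2-fold lower number from compound 2 to compound 4 (0.07 log units; within the scatter), does not separate 1-(thiophen-2-yl)ethyl from (furan-2-yl)methyl. No measurement is available that would explain the lower number of compound 4. 

On these data alone, the change from compound 2 alters the ring and the chain carbon together, so the share of each remains open. As far as these compounds go, how a pyridin-2-yl or a thiophen-3-yl group would behave on this carbon also remains open.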